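The source may report more compounds than this note shows. Statements on the series, on what has been measured and on what is new or still open speak of the compounds shown alone.

Three compounds have been measured in a functional assay on ileum (Cavia porcellus) for antagonist activity, with a stated time of 30 s (on this read-out higher numbers stand for weaker inhibition and lower numbers for stronger inhibition), so far:

- compound 1 `O=C(O)c1cc(=O)c2c(OCCOc3ccccc3)cccc2o1` gives 100 ug/mL in this read-out
- compound 2 `O=C(O)c1cc(=O)c2cc(OCCCOc3ccccc3)ccc2o1` gives 3.3 ug/mL in this read-out
- compound 3 `O=C(O)c1cc(=O)c2cc(CCCc3ccccc3)ccc2o1` gives 3 ug/mL in this read-out

Compound 3 (3 ug/mL) and compound 2 (3.3 ug/mL) lie within the usual scatter of each other, so neither can be ranked over the other. Compound 1 (100 ug/mL) carries a much higher number than compound 3, a gap well beyond that scatter.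

The next compound, compound 4 `O=C(O)c1cc(=O)c2cc(CCCCCc3ccccc3)ccc2o1`, has not yet been measured. It differs from compound 3 by phenethyl in place of phenyl on a saturated chain carbon, three bonds along the chain from an aromatic carbon.

Among the measured compounds shown here, no two measured compounds differ in one place alone, so the data give no direct guide to the size of this step. Compound 2 (3.3 ug/mL) and compound 3 (3 ug/mL) do show that two different chains can give matching values. In this assay the expectation is therefore no step beyond the scatter, with only a slight lean towards stronger inhibition. The expected change is a 1.5-fold lower number from compound 3 to compound 4 (0.18 log units; within the scatter) on this estimate. The estimate for compound 4 is 2 ug/mL as a middle value, within an expected range (0.6 ug/mL to 8 ug/mL).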

Compound 4, half-maximal inhibitory concentration: 4.5 ug/mL
Beside the measured number, compound 4's estimate is 2.3-fold (0.35 log units) below it; the range from low to high includes it.
By their numbers in this assay, from the lowest: compounds 3, 2 and 4 (each within the scatter of the next); then compound 1.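

Among the compounds shown here, the change gives a 1.5-fold higher number from compound 3 to compound 4 (0.18 log units; within the scatter) in this assay, the first comparison between compounds that differ in one place alone. On this read-out, phenethyl and phenyl on a saturated chain carbon, three bonds along the chain from an aromatic carbon, cannot be ranked, so this position accepts either group without a step beyond the scatter. No measurement at hand bears on why the two groups read alike.

From the compounds shown here alone, what stays open is how far this acceptance extends: whether a longer chain ending in phenyl, or an amine or a hydroxyl group in place of the phenyl, would still read alike in this assay. Going by these compounds, it is also open whether the same exchange of phenyl for phenethyl would give a step of similar size on a chain of a different kind.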